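This account rests on a few compounds, and the source may have more. Where it says the series, first, only, none or still open, it means among the compounds named here.

In a functional assay on MDA-MB-436 cells (Homo sapiens) for antiproliferative activity, read by MTT assay, with a stated time of 48 h (a higher number here means a weaker inhibitor, a lower number a stronger inhibitor), compound 1 `C=CS(=O)(=O)N1CCN(c2ncnc3sc(-c4ccc(C(F)(F)F)cc4)cc23)CC1` gives 7080 nM and compound 2 `C=CS(=O)(=O)N1CCN(c2ncnc3sc(-c4ccc(N5CCN(C)CC5)cc4)cc23)CC1` gives 8760 nM, two values that lie within the scatter of each other. Compound 3 `C=CS(=O)(=O)N1CCN(c2nc(OC[C@H]3CCCN3C)nc3sc(-c4ccc(N5CCN(C)CC5)cc4)cc23)CC1` gives 540 nM, well apart from both. Compound 2 therefore carries the highest of the three numbers, though only compound 3 is clearly separated from it. The next compound, compound 4 `CN1CCN(c2ccc(-c3cc4c(N5CCN(S(=O)(=O)N6CCCCC6)CC5)ncnc4s3)cc2)CC1`, starts from compound 2 and makes one change: piperidin-1-yl in place of vinyl on a sulfonyl sulfur.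

Neither measured step touches that place. The step of a 1.2-fold higher number from compound 1 to compound 2 (0.09 log units; within the scatter) exchanged trifluoromethyl for 4-methylpiperazin-1-yl and left the number within the scatter. The large step of a 16-fold lower number from compound 2 to compound 3 (1.21 log units; beyond the scatter) came with the (1-methylpyrrolidin-2-yl)methoxy group, which compound 4 does not carry. Going by the values given here, no measured compound here lacks the vinyl, so the data give no size or direction for this exchange. No step beyond the scatter is therefore expected in this assay, although the uncertainty is wide. The expected change is a 1.0-fold lower number from compound 2 to compound 4 (0.01 log units; within the scatter). For compound 4 the estimated value is 8500 nM, with an expected range from 3000 nM to 25000 nM.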

Compound 4, half-maximal inhibitory concentration: 7570 nM
Compound 4: the middle estimate sits 1.1-fold (0.05 log units) above what was measured, and the stated range covers the measured number.
By their numbers in this assay, from the lowest: compound 3; then compounds 1, 4 and 2 (each within the scatter of the next).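

In this assay putting piperidin-1-yl in place of vinyl on the sulfonyl sulfur gives a 1.2-fold lower number from compound 2 to compound 4 (0.06 log units; within the scatter) and so does not separate the two compounds. Going by these compounds alone, this is the first reading at this position, where every earlier compound carries the vinyl: a group with one six-membered non-aromatic ring and no double bond outside aromatic rings stands there with no change beyond the scatter, so in this pair the vinyl is not needed for a number at the level of compound 2. The data shown offer no measured property that bears on this result.

Going by these compounds, it remains open whether the same exchange would also leave the number unresolved on the background of compound 3, which carries the (1-methylpyrrolidin-2-yl)methoxy group and gives 540 nM in this assay, since a small effect could go unseen at the level of compound 2. Also open, on these data alone, is how other groups on the sulfonyl sulfur, such as a plain methyl, a dimethylamino group or a morpholin-4-yl ring, would compare with vinyl and piperidin-1-yl.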